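A few compounds are considered here, and "the series" means these few. Any claim that something is new, unique, unknown or untested is made for them only; others in the source may bear on it.

In a functional assay on U-937 cells (Homo sapiens) for cytotoxicity, read by MTT assay, with a stated time of 48 h (on this read-out higher numbers stand for weaker inhibition and lower numbers for stronger inhibition), compound 1, `Fc1ccc2nc(Nc3nc4ccccc4s3)sc2c1`, gives 40600 nM; 43500 nM (2 entries), and the several entries of compound 1 in this assay, 40600 nM; 43500 nM (2 entries) shows how closely its repeated entries agree. Within the data shown here, compound 2, `CCOc1ccc2nc(Nc3nc4ccc(F)cc4s3)sc2c1`, is the only other compound with a number here; in this assay compound 2 gives 26600 nM, and a further entry for it gives no single number. Compound 3, `Cc1ccc2nc(Nc3nc4ccc(F)cc4s3)sc2c1`, differs from compound 2 by methyl in place of ethoxy on an aromatic carbon. Among the measured compounds shown here, no measured pair with a single change is available, so the expected step of a 1.1-fold higher number from compound 2 to compound 3 (0.05 log units; within the scatter) is set at none beyond the usual scatter. On that basis compound 3 is estimated at 30000 nM, with a range from 12000 nM to 75000 nM.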

Compound 3, half-maximal inhibitory concentration: > 50000 nM
Compound 3 was reported as a limit; the forecaster's own chance of this, stated with the estimate: 25%; middle value at least 1.6-fold (0.22 log units) away from the limit.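

Methyl in place of ethoxy on this aromatic carbon gives an at least 1.8-fold higher number from compound 2 to compound 3 (0.27 log units; that floor lies within the scatter) in this assay and is the first step here between compounds that differ in one place. With that floor inside the scatter, the change is not shown to weaken the effect, though it brings no lower number. Compound 3 is reported only as a limit, so the true size of the step cannot be read: the limit of > 50000 nM in this assay, at which 1 of the 3 values shown sits.

From the compounds shown here alone, whether an amine, a carboxylic acid or a longer alkoxy chain on this carbon would give a lower number than ethoxy stays open.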